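Chloro in place of nitro: notes on the series

This account rests on a few compounds, and the source may have more. Where it says the series, first, only, none or still open, it means among the compounds named here.

In a functional assay on C6 cells (Rattus norvegicus) for inhibition, read by sulforhodamine B assay, with a stated time of 72 h (on this read-out lower numbers stand for an effect already at smaller amounts and higher numbers for an effect only at larger amounts of compound), compound 1 `O=C(/C=C/c1ccc([N+](=O)[O-])o1)c1ccc(N2CCCC2)cc1` gives 16400 nM while compound 2 `O=C(/C=C/c1ccc([N+](=O)[O-])s1)c1ccc(-n2ccnc2)cc1` gives 1900 nM as the lower of the two numbers, a gap beyond the scatter. Compound 3 `O=C(/C=C/c1ccc(Cl)s1)c1ccc(-n2ccnc2)cc1` has chloro in place of nitro on an aromatic carbon next to the ring sulfur (chloro in place of nitro on an aromatic carbon). For the measured compounds named here, no measured step between compounds differing in one place is available as a guide. The expected move in this assay is toward a higher number and beyond the scatter, estimated as a 3.2-fold higher number from compound 2 to compound 3 (0.50 log units; beyond the scatter) for this change. For compound 3 the estimated value is 6000 nM within an expected range of 2000 nM to 25000 nM in this series.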

Compound 3, half-maximal effective concentration: 14500 nM
Compound 3: the middle estimate sits 2.4-fold (0.38 log units) below what was measured; the range from low to high includes it.
By their numbers in this assay, from the lowest: compound 2; then compounds 3 and 1 (each within the scatter of the next).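

Chloro in place of nitro on an aromatic carbon next to the ring sulfur gives, in this assay, a 7.6-fold higher number from compound 2 to compound 3 (0.88 log units; beyond the scatter), the first step in the series that isolates one place, since compound 1 and compound 2 differ in more than one. The group at this position therefore matters to the read-out, though compound 3 with chloro still gives 14500 nM without nitro. No measurement at hand gives a reason for this step.

Going by these compounds, how an amine or a methyl at this position would compare with nitro and chloro stays open. Also open, on these data alone, is whether the same change moves the number similarly on the core of compound 1.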